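A Methoxy for a Chlorine on the Benzylamine Side

The source may hold more compounds than are shown below. What is called first, only, known or untested is meant among the compounds shown, and "the series" means these compounds.

Three close relatives share one core, and they are compared in a functional assay on Chem-3 cells for antagonist activity at metabotropic glutamate receptor 1 (Homo sapiens), read by fluorescence and calcium flux; on this read-out lower numbers stand for stronger inhibition and higher numbers for weaker inhibition. Compound 1 `N#Cc1c(NCc2ccc(F)cc2)sc2c1CCN(C(=O)c1ccc(F)cc1)C2` carries a 4-fluorobenzyl group on the amine, and in this assay compound 1 gives "not determined" (no result reported), so no result was reported for it. Compound 2 `N#Cc1c(NCc2cccc(F)c2)sc2c1CCN(C(=O)c1ccc(F)cc1)C2` moves the fluorine to the other position of that ring, and in this assay compound 2 gives 2380 nM. Compound 3 `N#Cc1c(NCc2ccc(Cl)cc2)sc2c1CCN(C(=O)c1ccc(F)cc1)C2` replaces the fluorine of compound 1 with chlorine; in this assay compound 3 gives "not determined" (no result reported), so for compound 3, as for compound 1, no single number stands in this assay, where compound 3 stands cannot be placed on the scale at all, and only compound 2 anchors the series.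

Compound 4 `COc1cccc(CNc2sc3c(c2C#N)CCN(C(=O)c2ccc(F)cc2)C3)c1` is the next variation: 3-methoxyphenyl in place of 4-chlorophenyl on a saturated chain carbon bound to a nitrogen on an aromatic ring. Among the measured compounds shown here, no measured pair shows what such a change does here. For the measured compounds named here, with no anchor for compound 3 itself, the expectation for compound 4 has to lean on compound 2, the only number in hand, and on the fact that both compound 2 and compound 4 carry their substituent at the same position of the benzyl ring. The expected outcome is therefore a value in the same region as compound 2, with no step in either direction that would clearly exceed the scatter. Compound 4 is estimated at 2500 nM in this assay, with a plausible range from 800 nM to 8000 nM.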

Compound 4, half-maximal inhibitory concentration: 3090 nM
Beside the measured number, compound 4's estimate is 1.2-fold (0.09 log units) below it, within the range that was stated.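

In this assay, among the compounds shown here, methoxy in place of fluoro on an aromatic carbon gives a 1.3-fold higher number from compound 2 to compound 4 (0.11 log units; within the scatter), the first step that can be read at all, and it shows that this side of the molecule takes either group with no difference that stands out from repeat measurements. Compound 1 and compound 3 carry no number, so every step that starts or ends at them, including the change from 4-chlorobenzyl to 3-methoxybenzyl, cannot be read, and this result says nothing about what chlorine contributes. No further measurement bears on why compound 2 and compound 4 read alike.

From the compounds shown here alone, the two numbers in hand cover only a narrow slice of what could sit on the benzyl ring, so it remains open whether any group there can shift the value beyond the scatter in either direction. A dimethylamino group or a carboxylic acid in place of the methoxy, or a longer chain in place of the benzyl carbon, would test this place more sharply than the swap seen here.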